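Replacing Bromine with Propylcyclohexyl on the Shared Core

The source may hold more compounds than are shown below. What is called first, only, known or untested is meant among the compounds shown, and "the series" means these compounds.

Compound 1, `O=c1cc(Cn2cc(CCCCO)nn2)c2ccc(O)cc2o1`: > 100000 nM in a functional assay on HepG2 cells (Homo sapiens) for inhibition, read by MTT assay, with a stated time of 72 h; a higher number here means a weaker inhibitor, a lower number a stronger inhibitor
Compound 2, `CC(C)(C)c1cn(Cc2cc(=O)oc3cc(O)ccc23)nn1`: > 100000 nM in this assay
Compound 3, `O=c1cc(Cn2cc(-c3ccc(Br)cc3)nn2)c2ccc(O)cc2o1`: 61100 nM in this assay

For compound 1 the value > 100000 nM is a limit of the assay, not a number. For compound 2 the value > 100000 nM is likewise only a limit. Going by the values given here, compound 3 is therefore the single compound with a measured number in this assay, at 61100 nM. The three compounds share one core and differ only in the group on the aromatic carbon of the triazole. The step that the two limits leave unreadable from compound 1 to compound 2 cannot be read because both values sit at the limit of > 100000 nM in this assay, at which 2 of the 3 values shown sit. Among the compounds with values here, the steps of an at least 1.6-fold lower number from compound 1 to compound 3 (0.21 log units; that floor lies within the scatter) and an at least 1.6-fold lower number from compound 2 to compound 3 (0.21 log units; that floor lies within the scatter) show that the 4-bromophenyl group gives the only number below that limit.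

Compound 4, `CCCC1CCC(c2ccc(-c3cn(Cc4cc(=O)oc5cc(O)ccc45)nn3)cc2)CC1`, changes that group further: 4-propylcyclohexyl in place of bromo on an aromatic carbon. Within the data shown here, no measured step touches this position; all three measured changes swap the whole group on the triazole carbon, so nothing here shows what a larger substituent on the bromophenyl ring does. The step of a 1.7-fold lower number from compound 3 to compound 4 (0.24 log units; within the scatter) is therefore expected to be small and uncertain. Compound 4 is estimated to give 35000 nM in this assay, within a range from 6000 nM to 150000 nM.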

Compound 4, half-maximal inhibitory concentration: 30400 nM
The estimate for compound 4 lay 1.2-fold (0.06 log units) above the measured number, within the range that was stated.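

Compound 3 and compound 4 are the first pair shown that differ on the six-membered aromatic ring itself, rather than in the whole group carried on the shared core, so they are the first to say anything about this position. Bromo, with 1 heavy atom, gives way to 4-propylcyclohexyl, with 9 heavy atoms and a non-aromatic ring, and the outcome is a 2.0-fold lower number from compound 3 to compound 4 (0.30 log units; within the scatter), so this much larger group leaves the reading in this assay unchanged within the scatter. Compound 1 and compound 2 remain the two compounds without a number, each holding only a limit: the limit of > 100000 nM in this assay, at which 2 of the 4 values shown sit.

From the compounds shown here alone, it remains open whether a group carrying other atoms at this place, such as an amine or a carboxylic acid, would move the number beyond the scatter. The compounds shown also leave open what a plain phenyl ring, with hydrogen in place of bromo, would give, and what a longer chain in place of the propyl on the cyclohexyl ring would do.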